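Amide side chains: from compound 3 to compound 4

A few compounds are considered here, and "the series" means these few. Any claim that something is new, unique, unknown or untested is made for them only; others in the source may bear on it.

Measured in a functional assay on BXPC-3 cells (Homo sapiens) for antiproliferative activity, read by MTT assay, with a stated time of 24 h; on this read-out lower numbers stand for stronger inhibition and higher numbers for weaker inhibition:
- compound 1 `CCn1c(C(=O)N[C@H](C)CO)ccc1C(CC)(CC)c1ccc(OCS(=O)(=O)c2ccccc2)c(C)c1`: 10000 nM
- compound 2 `CCn1c(C(=O)N[C@@H](CO)CCO)ccc1C(CC)(CC)c1ccc(OCS(=O)(=O)c2ccccc2)c(C)c1`: > 50000 nM (a limit of the assay, not a number)
- compound 3 `CCn1c(C(=O)N[C@@H](C(=O)O)C(C)C)ccc1C(CC)(CC)c1ccc(OCS(=O)(=O)c2ccccc2)c(C)c1`: 13900 nM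

Compound 3 gives 13900 nM in this assay, and the step to it stays within the scatter: a 1.4-fold higher number from compound 1 to compound 3 (0.14 log units; within the scatter). Compound 4 `CCn1c(C(=O)N[C@H](CC(=O)O)C(=O)O)ccc1C(CC)(CC)c1ccc(OCS(=O)(=O)c2ccccc2)c(C)c1` is still unmeasured. Its difference from compound 3 is carboxymethyl in place of isopropyl on a saturated chain carbon bound to an amide-type nitrogen and a carbonyl carbon. In words, this is carboxymethyl in place of isopropyl on a saturated chain carbon bound to an amide-type nitrogen and a carbonyl carbon, so 1-carboxy-2-methylpropyl becomes 1,2-dicarboxyethyl.

Among the compounds with values here, no measured step makes this exact change, so the nearest evidence is indirect. Exchanging the side chain carried no shift beyond the scatter in a 1.4-fold higher number from compound 1 to compound 3 (0.14 log units; within the scatter). Adding hydroxymethyl did, in an at least 5.0-fold higher number from compound 1 to compound 2 (0.69 log units; beyond the scatter), and the reverse comparison gives an at least 3.5-fold lower number from compound 2 to compound 3 (0.55 log units; beyond the scatter). Both of these involve a limit, so their true size is open. Compound 4 also gains a group on the side chain, which points to a modest move towards weaker inhibition, as with compound 2 in an at least 5.0-fold higher number from compound 1 to compound 2 (0.69 log units; beyond the scatter). The expected step is a 1.8-fold higher number from compound 3 to compound 4 (0.25 log units; within the scatter). Compound 4 may also sit at the limit of > 50000 nM in this assay, at which 1 of the 3 values shown sits, and then only a limit would be reported. For compound 4 the estimated value is 25000 nM, with an expected range of 10000 nM to 50000 nM.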

Compound 4, half-maximal inhibitory concentration: > 50000 nM
Compound 4: a limit, no number (the forecaster's own chance of this, stated with the estimate: 35%); at least 2.0-fold (0.30 log units) between middle value and limit.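

Carboxymethyl in place of isopropyl on a saturated chain carbon bound to an amide-type nitrogen and a carbonyl carbon gives an at least 3.5-fold higher number from compound 3 to compound 4 (0.55 log units; beyond the scatter) in this assay and, measured against the hydroxyl side chain, an at least 5.0-fold higher number from compound 1 to compound 4 (0.69 log units; beyond the scatter) in the same assay, whereas a 1.4-fold higher number from compound 1 to compound 3 (0.14 log units; within the scatter) had shown no shift beyond the scatter. Compound 4 is reported only as a limit, so both of its steps give a minimum size, and the carboxylic acid of compound 3 alone does not carry the loss seen with 1,2-dicarboxyethyl. The added carboxymethyl now parallels the added hydroxymethyl of an at least 5.0-fold higher number from compound 1 to compound 2 (0.69 log units; beyond the scatter) in reaching the top of the range, and the step between compound 2 and compound 4 cannot be read, so these two side chains cannot be ordered: the limit of > 50000 nM in this assay, at which 2 of the 4 values shown sit.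

On these data alone, whether aminomethyl or a longer alkyl chain in place of isopropyl would keep a measurable number in this assay remains open. The same holds for the methyl ester of the carboxymethyl group, which would show whether the free carboxylic acid or the added chain length goes with the limit.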